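The compounds below may be only part of what the source reports. "The series", "measured", "known", "first", "only" and "open" are said of these compounds alone.

The series shares one core, first seen in compound 1 `Cc1ccccc1-n1nc(C)c2c1NC(=O)[C@H](C)S[C@@H]2c1ccc(-c2ccccc2)cc1`. In an assay on isolated protein for agonist activity at Bile acid receptor (Homo sapiens), read by AlphaScreen, with a stated time of 30 min (a higher number here means that more compound is needed for the effect, a lower number that less compound is needed), compound 1 gives 990 nM. Compound 2 `COC(=O)c1cccc(-c2ccc([C@H]3S[C@@H](C)C(=O)Nc4c3c(C)nn4-c3ccccc3C)cc2)c1` carries a methyl ester, and in this assay compound 2 is reported as "not active" (no number reported). Going by the values given here, compound 3 `Cc1ccccc1-n1nc(C)c2c1NC(=O)[C@H](C)S[C@@H]2c1ccc(-c2ccc(C(=O)O)cc2)cc1` carries the free carboxylic acid, and in this assay compound 3 is likewise reported as "not active" (no number reported), so compound 3 stands without a number of its own, as one of two such entries in this set, and it offers no measured step to compare against. Compound 4 `Cc1ccccc1-n1nc(C)c2c1NC(=O)[C@H](C)S[C@@H]2c1ccc(OCc2ccccc2)cc1` differs from compound 3 in one place: benzyloxy in place of 4-carboxyphenyl on an aromatic carbon. Among the compounds with values here, no step between measured compounds matches this change. Since the acid-bearing compounds 2 and 3 both lack a number while compound 1, which carries no acid, gives 990 nM, the expectation in this assay is a return to a measurable value rather than a step whose size can be read from the data. Compound 4 is expected to give about 1500 nM, within a range from 300 nM to 10000 nM.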

Compound 4, half-maximal effective concentration: "not active" (no number reported)
Compound 4: no number reported; no gap can be computed for the estimate.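

Compound 4, like compound 3, is reported as "not active" in this assay and carries no number, so no step can be read between them. No measurement shown offers an explanation for this result. The compounds shown leave open how benzyloxy and 4-carboxyphenyl compare on the shared core.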